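This account rests on a few compounds, and the source may have more. Where it says the series, first, only, none or still open, it means among the compounds named here.

Within the data shown here, in a functional assay on NCI-H1299 cells (Homo sapiens) for cytotoxicity, read by a luciferase reporter and CellTiter-Glo, with a stated time of 72 h (a lower number here means a stronger inhibitor, a higher number a weaker inhibitor), compound 1 `COc1ccc(C2=NN(c3ccccc3Cl)C(c3cccc(Cl)c3)C2)cc1` gives 7200 nM, the only number in this small series. Compound 2 `COc1ccc(C2=NN(c3ccccc3Cl)C(c3ccccc3Cl)C2)cc1` has no single number to stand on, and the entry for compound 2 reads "not determined" (no result reported). The same is true of compound 3 `COc1ccc(C2=NN(c3ccc(Cl)cc3)C(c3ccccc3Cl)C2)cc1`, and the entry for compound 3 reads "not determined" (no result reported). The step followed here leads to compound 4 `COc1cccc(C2=NN(c3ccccc3Cl)C(c3ccccc3Cl)C2)c1`, which has the same atoms as compound 2, joined differently: 3-methoxyphenyl in place of 4-methoxyphenyl on a carbon with a double bond to nitrogen. In words, 3-methoxyphenyl replaces 4-methoxyphenyl on a carbon with a double bond to nitrogen. Among the measured compounds shown here, no step between measured compounds is available to size this change, and the data point in no direction. The expectation in this assay is therefore a step from compound 2 no larger than the scatter, with no direction assigned. The only anchor for the level is compound 1 at 7200 nM, so the range has to stay wide. Compound 4 is expected at about 7000 nM, with an estimated range from 2500 nM to 20000 nM.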

Compound 4, half-maximal inhibitory concentration: 13600 nM
Compound 4: middle estimate off by 1.9-fold (0.29 log units), on the low side; low and high end bracket the measured number.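

Compound 2 has no single number to set against compound 4, so no new step can be read from this result. The compounds shown leave open what 3-methoxyphenyl in place of 4-methoxyphenyl does to potency. No further evidence bears on the result.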